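The source may hold more compounds than are shown below. What is called first, only, known or untested is meant among the compounds shown, and "the series" means these compounds.

In an ADME assay on S9 fraction from liver (Rattus norvegicus) for metabolic stability, with a stated time of 1 h (on this read-out lower numbers stand for a less stable compound and higher numbers for a more stable compound), compound 2 `COc1ncncc1CNc1cc(N[C@H]2CC[C@@H](O)CC2)c(C#N)cn1` gives 89%, and compound 1 `CC(C)(F)c1ncncc1CNc1cc(N[C@H]2CC[C@@H](O)CC2)c(C#N)cn1` gives 81%. With only these two numbers available, compound 2 stands within the scatter of compound 1. The next compound, compound 3 `CC(C)(C)Oc1ncncc1CNc1cc(N[C@H]2CC[C@@H](O)CC2)c(C#N)cn1`, has not yet been measured. It is reached from compound 2 by one change: tert-butyl in place of methyl on an oxygen on an aromatic ring. In other words, methoxy becomes tert-butoxy. Going by the values given here, the only measured step that bears on this is a number 8 percentage points higher from compound 1 to compound 2 (within the scatter), which exchanges 1-fluoro-1-methylethyl for methoxy and stays within the scatter. Among the compounds with values here, that step gives only limited guidance, since no measured compound carries tert-butoxy, so no step beyond the scatter is expected. The estimated change is a number 9 percentage points lower from compound 2 to compound 3 (within the scatter). For compound 3 the expected value is 80%, with an estimated range of 62% to 92%.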

Compound 3, percent of the compound remaining: 21%
For compound 3 the middle estimate is 59 percentage points above the measured one, and the stated range ends above it.
By their numbers in this assay, from the lowest: compound 3; then compounds 1 and 2 (each within the scatter of the next).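

In this assay, going by these compounds alone, the group on the oxygen at this position turns out to matter a great deal: methoxy to tert-butoxy is a large step (a number 68 percentage points lower from compound 2 to compound 3 (beyond the scatter)), whereas the only earlier step stayed within the scatter. Tert-butoxy also stands well apart from 1-fluoro-1-methylethyl (a number 60 percentage points lower from compound 1 to compound 3 (beyond the scatter)), so among these compounds a branched group alone does not go with a low number, and compound 1 goes against any such reading. Nothing available bears on the reason for this loss.

The compounds shown leave open whether ethoxy or isopropoxy would fall close to compound 2 or close to compound 3. They also leave open whether the low number belongs to tert-butyl on oxygen specifically or would return with cyclopropoxy.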